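Ethoxy to Methoxy on a Cell-Growth Assay

A few compounds are considered here, and "the series" means these few. Any claim that something is new, unique, unknown or untested is made for them only; others in the source may bear on it.

Measured compounds:
compound 1 `CCOc1ccccc1N1C(=O)C(C)SC1c1cccc(C(=O)NCCCCc2ccccc2)c1`: 85%
compound 2 `COc1ccccc1N1C(=O)CSC1c1cc(F)cc(C(=O)O)c1`: 0%

Both compounds were tested in a functional assay on SJSA-1 cells (Homo sapiens) for inhibition, read by CCK-8 assay, with a stated time of 72 h, tested at 1 uM; on this read-out higher numbers stand for more inhibition at the one concentration tested (going by the name of the read-out) and lower numbers for less inhibition. Compound 1 gives 85%, the higher of the two numbers, while compound 2 gives 0%, a gap that lies well beyond the usual scatter. Among the measured compounds shown here, compound 2 differs from compound 1 in several places at once, so the two values show only that the pair sits far apart in this assay, not which change matters.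

Compound 3 `COc1ccccc1N1C(=O)C(C)SC1c1cccc(C(=O)NCCCCc2ccccc2)c1` has not yet been measured. It differs from compound 1 in one place only: hydrogen in place of methyl on a saturated chain carbon bound to an oxygen on an aromatic ring. The rest of the structure, including the shared core and the amide side chain, is kept.

For the measured compounds named here, no measured pair in this set isolates such a change, so the expectation rests on the small size of the difference. The step of a number 7 percentage points lower from compound 1 to compound 3 (within the scatter) is expected to be small, most likely a modest loss or no change beyond the scatter. Compound 3 is expected to give 78%, within a range from 55% to 95%.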

Compound 3, a percentage reported as inhibition, at one concentration (the size of the read-out at that concentration, not a potency): 84%
Compound 3: the middle estimate sits 6 percentage points below what was measured; the range from low to high includes it.
By their numbers in this assay, from the lowest: compound 2; then compounds 3 and 1 (each within the scatter of the next).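

In this assay, going from 2-ethoxyphenyl to 2-methoxyphenyl gives a number 1 percentage points lower from compound 1 to compound 3 (within the scatter), so the two compounds cannot be told apart on this read-out. Among the compounds shown here, this is the only comparison here that isolates a single place, and it shows that the methyl on a saturated chain carbon bound to an oxygen on an aromatic ring can be replaced by hydrogen with no change that rises above the scatter, although a reading at one concentration gives the size of the inhibition and not a potency. Nothing available explains why the two compounds read alike.

From the compounds shown here alone, how much further this position can be altered stays open, since a longer chain such as propoxy, or a carboxylic acid at the end of that chain, could behave quite differently from ethoxy and methoxy. Compound 2 still differs from compound 1 in several places at once, so which of those differences lies behind the reading of compound 2 at 0% also remains unresolved.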